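The compounds below may be only part of what the source reports. "The series", "measured", "known", "first", "only" and "open" are said of these compounds alone.

Three compounds share one core and differ at two spots. Compound 3 `Cc1ncnc2c1c(-c1ccsc1)cn2[C@@H]1O[C@H](CO)[C@@H](O)[C@H]1O` carries a methyl group and a thiophen-3-yl ring; compound 1 `Cc1ncnc2c1c(-c1ccoc1)cn2[C@@H]1O[C@H](CO)[C@@H](O)[C@H]1O` keeps the methyl but bears a furan-3-yl ring instead; compound 2 `CNc1ncnc2c1c(-c1ccsc1)cn2[C@@H]1O[C@H](CO)[C@@H](O)[C@H]1O` keeps the thiophen-3-yl ring but carries methylamino where compound 3 has methyl. In a functional assay on HepG2 cells (Homo sapiens) for antiproliferative activity, read by XTT assay, with a stated time of 72 h (on this read-out higher numbers stand for weaker inhibition and lower numbers for stronger inhibition), compound 3 gives 4720 nM and compound 1 gives 5320 nM. For compound 2 this assay reports only a limit, > 20000 nM. The swap of rings, (furan-3-yl in place of thiophen-3-yl on an aromatic carbon), made a step of a 1.1-fold higher number from compound 3 to compound 1 (0.05 log units; within the scatter). The cores of compound 2 and compound 3 differ by methylamino in place of methyl on an aromatic carbon, and this step is an at least 4.2-fold lower number from compound 2 to compound 3 (0.62 log units; beyond the scatter), which rests on (the limit of > 20000 nM in this assay, at which 1 of the 3 values shown sits). Compound 4 `CNc1ncnc2c1c(-c1ccoc1)cn2[C@@H]1O[C@H](CO)[C@@H](O)[C@H]1O` is not yet measured; it arises from compound 2 by the same change, (furan-3-yl in place of thiophen-3-yl on an aromatic carbon). Because the earlier swap gave a 1.1-fold higher number from compound 3 to compound 1 (0.05 log units; within the scatter), the step that the limit leaves unreadable from compound 2 to compound 4 is expected to be small as well. Compound 4 is therefore estimated at 30000 nM, between 12000 nM and 80000 nM, and this assay is expected most likely to report only a limit for it again.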

Compound 4, half-maximal inhibitory concentration: > 20000 nM
Compound 4: a limit, no number (the forecaster's own chance of this, stated with the estimate: 75%); the middle value is on the limit's open side.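

Going from a methyl group to a methylamino group moves the result the same way with a furan-3-yl ring as with a thiophen-3-yl ring: in this assay there is an at least 3.7-fold higher number from compound 1 to compound 4 (0.57 log units; beyond the scatter). The change therefore carries over between these two cores in direction, with a weaker result beyond the usual scatter each time, but only a lower bound on its size can be given for either core: the same change on two cores in this assay, an at least 4.2-fold lower number (0.62 log units; beyond the scatter) from compound 2 to compound 3 and an at least 3.7-fold lower number (0.57 log units; beyond the scatter) from compound 4 to compound 1; the limit leaves it open whether they differ So whether the change costs the same amount on both cores stays unknown, and the step between the two methylamino compounds, which swaps thiophen-3-yl for furan-3-yl, cannot be read: the limit of > 20000 nM in this assay, at which 2 of the 4 values shown sit.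

On these data alone, how far the true values of compound 2 and compound 4 lie past the limit remains open. Also open, as far as these compounds go, is how an amino group, a methoxy group or an ethyl chain would behave in place of methyl, and whether a phenyl ring would match the two five-membered rings.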